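The source may report more compounds than this note shows. Statements on the series, on what has been measured and on what is new or still open speak of the compounds shown alone.

Measured in an ADME assay on microsomes from liver (Homo sapiens) for metabolic stability, read by LC-MS; on this read-out higher numbers stand for a longer-lived compound and lower numbers for a shorter-lived compound:
- compound 1 `O=C(Nc1ccc(F)c(-c2nc3ncc(-c4ccc(F)cc4)cc3[nH]2)c1)N1CCCC1`: 0.203 h
- compound 2 `O=C(Nc1ccc(F)c(-c2nc3ncc(-c4cccnc4F)cc3[nH]2)c1)N1CCCC1`: > 1.5 h
- compound 3 `Cc1nc(C)c(C(=O)Nc2ccc(F)c(-c3nc4ncc(-c5ccccc5Cl)cn4n3)c2)o1`: > 1.5 h

The value for compound 2 is a limit and not a number. The value for compound 3 is also a limit. Compound 2 thus stands at the limit of > 1.5 h in this assay, at which 2 of the 3 values shown sit.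

Compound 4 `O=C(Nc1ccc(F)c(-c2nc3ncc(-c4ccccc4F)cc3[nH]2)c1)N1CCCC1` carries 2-fluorophenyl in place of 2-fluoropyridin-3-yl, (2-fluorophenyl in place of 2-fluoropyridin-3-yl on an aromatic carbon). Among the compounds with values here, the one measured step bearing on this is an at least 7.3-fold higher number from compound 1 to compound 2 (0.86 log units; beyond the scatter), which also led from a ring of carbon only to 2-fluoropyridin-3-yl. Compound 4 returns to a ring of carbon only, so a reversal of that step, beyond the scatter and towards a lower number, is expected. The expected step is an at least 4.2-fold lower number from compound 2 to compound 4 (0.63 log units; beyond the scatter). Compound 4 is estimated at 0.35 h, with an expected range of 0.13 h to 1.2 h.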

Compound 4, half-life: 0.285 h
Beside the measured number, compound 4's estimate is 1.2-fold (0.09 log units) above it; the measured number falls inside the stated range.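

In this assay, exchanging the ring nitrogen of 2-fluoropyridin-3-yl for carbon while the fluorine stays gives an at least 5.2-fold lower number from compound 2 to compound 4 (0.72 log units; beyond the scatter). Among the rings of carbon only, the place of the fluorine shows no clear effect, with a 1.4-fold higher number from compound 1 to compound 4 (0.15 log units; within the scatter). Compound 2 carries a limit and not a number: the limit of > 1.5 h in this assay, at which 2 of the 4 values shown sit.

The compounds shown leave open whether the fluorine is needed alongside the ring nitrogen, which an unsubstituted pyridin-3-yl would test. They also leave open whether a pyridin-4-yl or a pyrimidin-5-yl ring would do the same at this position.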